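The source may report more compounds than this note shows. Statements on the series, on what has been measured and on what is new or still open speak of the compounds shown alone.

Series notes. Compound 1 `COc1ccc(/C(=C(/CCNC(=O)NC2CCCCC2)c2ccccc2)c2ccccc2)cc1` and compound 2 `CCN(CC)C(=O)NCC/C(=C(\c1ccccc1)c1ccc(OC)cc1)c1ccccc1` share the same core and differ only in the group attached to the carbonyl carbon. In a functional assay on MDA-MB-231 cells (Homo sapiens) for cytotoxicity, read by MTT assay, with a stated time of 72 h (a higher number here means a weaker inhibitor, a lower number a stronger inhibitor), compound 1 returns only a limit of the assay, > 50000 nM. In this assay compound 2 gives 40700 nM. The step of an at least 1.2-fold lower number from compound 1 to compound 2 (0.08 log units; that floor lies within the scatter) is thus bounded on one side by a limit, and the limit of > 50000 nM in this assay, at which 1 of the 2 values shown sits, marks where that side sits. On the numbers shown compound 2 stands as the only compound with a measured value, the other entry being a limit.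

Compound 3 `COc1ccc(/C(=C(/CCNC(=O)N2CCCCC2)c2ccccc2)c2ccccc2)cc1` carries the change (piperidin-1-yl in place of diethylamino on a carbonyl carbon). Going by the values given here, the one measured step, cyclohexylamino to diethylamino, stayed within the scatter, and the new change again swaps one group for another on the same carbonyl carbon, so no step beyond the scatter is expected in this assay; the expected step of a 1.0-fold lower number from compound 2 to compound 3 (0.01 log units; within the scatter) is small. For compound 3 the estimate in this assay is 40000 nM, with a range from 15000 nM to 100000 nM, and a fair chance that only a limit is reported.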

Compound 3, half-maximal inhibitory concentration: > 50000 nM
Compound 3: no number, only a limit; the forecaster's own chance of this, stated with the estimate: 35%; middle value at least 1.2-fold (0.09 log units) away from the limit.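

In this assay the step of an at least 1.2-fold higher number from compound 2 to compound 3 (0.08 log units; that floor lies within the scatter) is only a floor, set by the limit that compound 3 returns, and it shows no change beyond the scatter when piperidin-1-yl replaces diethylamino on a carbonyl carbon. Compound 1 and compound 3 both return limits and no numbers, and the step between them cannot be read, which leaves the cyclohexylamino and piperidin-1-yl groups without a direct comparison at this position. With a third group on the same carbonyl carbon, compound 2 remains the only compound of the three with a measured value, and the limit now describes most of the series: the limit of > 50000 nM in this assay, at which 2 of the 3 values shown sit.

Going by these compounds, how far compound 1 and compound 3 actually lie from compound 2 remains open, as does whether any group on this carbonyl carbon, such as morpholin-4-yl or a longer chain ending in an amine, gives a number clearly clear of the limit. Also open, on these data alone, is what a change elsewhere on the shared core would do, for instance a hydroxyl group in place of the methoxy group.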